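The source may hold more compounds than are shown below. What is called first, only, known or untested is meant among the compounds shown, and "the series" means these compounds.

Two sulfonamides built on the same core have been tested in a functional assay on SGC-7901 cells (Homo sapiens) for antiproliferative activity, read by MTT assay, with a stated time of 24 h; on this read-out lower numbers stand for stronger inhibition and higher numbers for weaker inhibition. Compound 1 `O=c1[nH]cc(S(=O)(=O)Nc2ccccc2-c2cn(-c3ccccc3)nn2)c(=O)[nH]1` gives in this assay a value of 11800 nM. Compound 2 `O=c1[nH]cc(S(=O)(=O)Nc2cccc(-c3cn(-c4ccccc4)nn3)c2)c(=O)[nH]1` carries the same phenyl-triazole arm but attached at a different point of the aniline ring, and in this assay compound 2 gives 17200 nM. This is the higher of the two numbers, yet the gap to compound 1 falls within the scatter, so the two compounds cannot be told apart on potency.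

Compound 3 `O=c1[nH]cc(S(=O)(=O)Nc2cccc(-c3cn(-c4cccc(Cl)c4)nn3)c2)c(=O)[nH]1` is the next candidate; it differs from compound 2 by one change: chloro in place of hydrogen on an aromatic carbon. Going by the values given here, nothing among the measured compounds shows what such a change does, so only a small step is expected in this assay, if any, and the estimated step of a 1.4-fold lower number from compound 2 to compound 3 (0.16 log units; within the scatter) leans modestly toward stronger inhibition without clearly leaving the scatter. Compound 3 is therefore estimated at 12000 nM, with a likely range from 5000 nM to 30000 nM.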

Compound 3, half-maximal inhibitory concentration: 3950 nM
Estimate against measurement, compound 3: 3.0-fold (0.48 log units) above; the whole stated range lies above it.
By their numbers in this assay, from the lowest: compound 3; then compounds 1 and 2 (each within the scatter of the next).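

Going from phenyl to 3-chlorophenyl gives a 4.4-fold lower number from compound 2 to compound 3 (0.64 log units; beyond the scatter) in this assay. The values of compound 1 and compound 2 lie within the scatter of each other and gave no sign that any change could move this read-out, whereas here one chlorine atom, meta to a large group, clearly shifts it toward stronger inhibition. Nothing available here explains how the chloro group produces this step.

From the compounds shown here alone, what stays open is whether this step belongs to chloro in particular, a question that a fluoro, methyl or methoxy group at this place would help to answer. Going by these compounds, it is equally open whether chloro would give a similar step on another carbon of this ring, or on the phenyl group of compound 1.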